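Swapping the Aryl Group on Compound 2 for Aminophenyl

The compounds below may be only part of what the source reports. "The series", "measured", "known", "first", "only" and "open" are said of these compounds alone.

Compound 1 `C/C(=N\Nc1nc2ccccc2nc1Cc1ccccc1)c1ccc(O)cc1`: 2.8 nM
Compound 2 `C/C(=N\Nc1nc2ccccc2nc1Cc1ccccc1)c1cccs1`: 64 nM

Of the compounds shown here, two sharing one core have been measured in an assay on isolated protein for inhibition of Amine oxidase [flavin-containing] A (Homo sapiens), read by spectrophotometry; on this read-out lower numbers stand for stronger inhibition and higher numbers for weaker inhibition. Compound 1 gives 2.8 nM, and compound 2 gives 64 nM. Going by the values given here, compound 2 stands at the higher of the two numbers, and the single measured step, a 23-fold higher number from compound 1 to compound 2 (1.36 log units; beyond the scatter), separates it from compound 1. Compound 3 `C/C(=N\Nc1nc2ccccc2nc1Cc1ccccc1)c1ccc(N)cc1` has not yet been measured; it differs from compound 2 by 4-aminophenyl in place of thiophen-2-yl on a carbon with a double bond to nitrogen. Among the compounds with values here, the one step that bears on this position is a 23-fold higher number from compound 1 to compound 2 (1.36 log units; beyond the scatter), in which 4-hydroxyphenyl gave way to thiophen-2-yl. Compound 3 brings back a six-membered aromatic ring of carbon only with 1 hydrogen-bond donor, so a large fall in this assay is expected, estimated as an 11-fold lower number from compound 2 to compound 3 (1.03 log units; beyond the scatter). Compound 3 is therefore expected to give 6 nM, with a range from 1.5 nM to 25 nM.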

Compound 3, half-maximal inhibitory concentration: 9.8 nM
Compound 3: the middle estimate sits 1.6-fold (0.21 log units) below what was measured; the range from low to high includes it.
By their numbers in this assay, from the lowest: compound 1; then compound 3; then compound 2.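

In this assay, restoring a six-membered aromatic ring of carbon only in place of the thiophen-2-yl recovers much of the earlier loss, with a 6.5-fold lower number from compound 2 to compound 3 (0.81 log units; beyond the scatter) at this position. The group on that ring also counts: amino in place of hydroxy on an aromatic carbon gives a 3.5-fold higher number from compound 1 to compound 3 (0.54 log units; beyond the scatter), so these two substituted phenyl groups are not equivalent here. No supporting data are available to explain either step.

The compounds shown leave open how an unsubstituted phenyl ring, a methoxy group or a dimethylamino group would compare with hydroxy and amino on that aromatic carbon. They also leave open whether a thiophene ring carrying an amino group would match the 4-aminophenyl.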